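The compounds below may be only part of what the source reports. "The series", "measured", "known", "first", "only" and "open" are said of these compounds alone.

Measured compounds:
Compound 1 `O=C(Nc1ccc(Cl)c(-c2nc3ccccc3[nH]2)c1)c1ccc(Br)o1` gives 85 nM in an in vitro functional assay on HEK293-A cells for antagonist activity at metabotropic glutamate receptor 5 (Rattus norvegicus), read by calcium flux; on this read-out higher numbers stand for weaker inhibition and lower numbers for stronger inhibition.
Compound 2 `COc1ccccc1C(=O)Nc1cccc(NC(=O)c2ccc(Cl)cc2)c1` gives > 30000 nM, which is a limit of the assay.
Compound 3 `O=C(Nc1cccc(NC(=O)c2cccc(Cl)c2)c1)c1ccc(Cl)cc1` gives > 30000 nM, again a limit of the assay.

Compound 3 therefore stands at the limit of > 30000 nM in this assay, at which 2 of the 3 values shown sit, so no number is known for it. Among the measured compounds shown here, the one step among the measured compounds, a step that the two limits leave unreadable from compound 2 to compound 3, cannot be read because the limit of > 30000 nM in this assay, at which 2 of the 3 values shown sit, hides both ends. Compound 4 `O=C(Nc1cccc(NC(=O)C2CCC2)c1)c1cccc(Cl)c1` differs from compound 3 by cyclobutyl in place of 4-chlorophenyl on a carbonyl carbon. No readable measured step bears on this change, so there is no ground to expect any step beyond the scatter. Compound 4 is expected to stay at the limit, with an estimate of 30000 nM and a range from 10000 nM to 100000 nM. The step from compound 3 to compound 4 is expected to be a number no higher from compound 3 to compound 4 (the limit leaves the size open).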

Compound 4, half-maximal inhibitory concentration: 5270 nM
Beside the measured number, compound 4's estimate is 5.7-fold (0.76 log units) above it; the whole stated range lies above it.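

Cyclobutyl in place of 4-chlorophenyl on a carbonyl carbon gives an at least 5.6-fold lower number from compound 3 to compound 4 (0.75 log units; beyond the scatter), so this place responds to a change in a way that could not be seen before, as the step between compound 2 and compound 3 cannot be read. A non-aromatic ring of carbon at this place thus still gives a measurable number. The size of the step remains only a minimum because the value of compound 3 is a limit of the assay: the limit of > 30000 nM in this assay, at which 2 of the 4 values shown sit.

The compounds shown leave open how a cyclopentyl ring, an open butyl chain or an amine would read at this carbonyl carbon. They also leave open whether cyclobutyl would give a readable step in place of the 2-methoxyphenyl of compound 2.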